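Metabotropic Glutamate Receptor 5 Modulators: One Ring Exchanged

The source may report more compounds than this note shows. Statements on the series, on what has been measured and on what is new or still open speak of the compounds shown alone.

Compound 1 `O=C1c2cc(COc3ccccc3)nn2CCN1c1ccc(F)cc1F`: 101%
Compound 2 `O=C1c2cc(COc3cccc(F)c3)nn2CCN1c1ccc(F)cc1`: 70%

In a functional assay on HEK293 cells for positive allosteric modulation of metabotropic glutamate receptor 5 (Homo sapiens), read by calcium flux (a lower number here means a smaller maximal response, a higher number a larger maximal response), compound 1 gives 101%, while compound 2 gives 70%. Compound 2 thus stands lowest of the two values, and its gap to compound 1 lies beyond the scatter. Compound 3 `O=C1c2cc(COc3ccc(F)cn3)nn2CCN1c1ccc(F)cc1` is not yet measured; it differs from compound 2 by 5-fluoropyridin-2-yl in place of 3-fluorophenyl on an oxygen on a saturated carbon. For the measured compounds named here, no measured pair shows this change, so its effect is unknown. The step of a number 10 percentage points higher from compound 2 to compound 3 (within the scatter) is expected to be small, within the scatter, with a slight upward lean. For compound 3 the estimate is 80%. Its expected range runs from 55% to 105%.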

Compound 3, largest response reached (Emax), in percent of the reference or control that the assay uses: 52%
For compound 3 the middle estimate is 28 percentage points above the measured one, outside the stated range (below it).
By their numbers in this assay, from the lowest: compound 3; then compound 2; then compound 1.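

For the compounds shown here, on an oxygen on a saturated carbon, exchanging 3-fluorophenyl for 5-fluoropyridin-2-yl gives the first readable step at this position in this assay: a number 18 percentage points lower from compound 2 to compound 3 (beyond the scatter). The largest response thus changes with this ring, and the entering ring, with its one hydrogen-bond acceptor, does not preserve the response of compound 2 70%. Nothing available gives a reason for this step.

Going by these compounds, whether the ring nitrogen or the placing of the fluorine carries the step stays open, as the two rings differ in both. On these data alone, how an unsubstituted pyridine or a cyclohexyl group would fare here is also open.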